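This account rests on a few compounds, and the source may have more. Where it says the series, first, only, none or still open, it means among the compounds named here.

Compound 1, `CC(O)(C[S+]([O-])c1ccc(C(F)(F)F)cc1)C(=O)Nc1ccc([N+](=O)[O-])cc1C(F)(F)F`: 25600 nM
Compound 2, `CC(O)(C[S+]([O-])c1ccccn1)C(=O)Nc1ccc([N+](=O)[O-])cc1C(F)(F)F`: > 100000 nM
Compound 3, `CC(O)(C[S+]([O-])c1ccc(OC(F)(F)F)cc1)C(=O)Nc1ccc([N+](=O)[O-])cc1C(F)(F)F`: > 100000 nM

In a functional assay on LNCaP cells (Homo sapiens) for antiproliferative activity (a lower number here means a stronger inhibitor, a higher number a weaker inhibitor), compound 1 gives 25600 nM. Compound 2 reaches only a limit of the assay, > 100000 nM. Compound 3 likewise sits at a limit and gives > 100000 nM; among the numbers shown it therefore stands at the weak end, without a number of its own. Two of the three values sit at the limit of > 100000 nM in this assay, at which 2 of the 3 values shown sit. The step of an at least 3.9-fold higher number from compound 1 to compound 3 (0.59 log units; beyond the scatter) and the step of an at least 3.9-fold higher number from compound 1 to compound 2 (0.59 log units; beyond the scatter) are both at least modest losses, while the step that the two limits leave unreadable from compound 2 to compound 3 cannot be read.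

Compound 4, `CC(O)(C[S+]([O-])c1ccccc1OC(F)(F)F)C(=O)Nc1ccc([N+](=O)[O-])cc1C(F)(F)F`, differs from compound 3 by 2-(trifluoromethoxy)phenyl in place of 4-(trifluoromethoxy)phenyl on a sulfur. Going by the values given here, no measured step exchanges 4-(trifluoromethoxy)phenyl for 2-(trifluoromethoxy)phenyl, so none bears directly on this change; what is known is that compound 3 already stands at a limit. Compound 4 is therefore expected to remain near that limit, with a step of a number no higher from compound 3 to compound 4 (the limit leaves the size open) that is not readable beyond the scatter. The value of compound 4 is estimated at 100000 nM, within 30000 nM to 300000 nM.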

Compound 4, half-maximal inhibitory concentration: 9090 nM
Estimate against measurement, compound 4: 11-fold (1.04 log units) above; measured number below the stated range.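

With the atoms unchanged, 2-(trifluoromethoxy)phenyl in place of 4-(trifluoromethoxy)phenyl on the sulfur gives a readable value in this assay, with an at least 11-fold lower number from compound 3 to compound 4 (1.04 log units; beyond the scatter), so where the group sits on the phenyl ring matters here, not only which atoms it brings. The other two new steps are an at least 11-fold lower number from compound 2 to compound 4 (1.04 log units; beyond the scatter) and a 2.8-fold lower number from compound 1 to compound 4 (0.45 log units; beyond the scatter), which makes compound 4 the strongest of the four in this assay. The step between compound 2 and compound 3 cannot be read, and the steps from those two compounds give only a minimum size, because both rest on an assay limit: the limit of > 100000 nM in this assay, at which 2 of the 4 values shown sit.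

The compounds shown leave open whether this gain belongs to the trifluoromethoxy group itself. A methoxy group or a chlorine in its place on the phenyl ring of compound 4 would test this.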